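The source may report more compounds than this note shows. Statements on the series, on what has been measured and on what is new or still open speak of the compounds shown alone.

Compound 1 `Cc1cc(=O)n(-c2cccc(F)c2)nc1C(=O)Nc1ccc(Oc2ncnc3sccc23)c(F)c1` and compound 2 `Cc1ccc(-n2nc(C(=O)Nc3ccc(Oc4ncnc5sccc45)c(F)c3)c(C)cc2=O)cc1` share one core and differ only in the group attached to an aromatic nitrogen. In a functional assay on A549 cells (Homo sapiens) for cytotoxicity, read by MTT assay, with a stated time of 72 h (on this read-out higher numbers stand for weaker inhibition and lower numbers for stronger inhibition), compound 1 gives 19500 nM. On these data alone, for compound 2 the same measurement returns only a limit of the assay, > 40000 nM, so its true number stays open (the limit of > 40000 nM in this assay, at which 1 of the 2 values shown sits). Replacing the 3-fluorophenyl group by a 4-methylphenyl group gave an at least 2.0-fold higher number from compound 1 to compound 2 (0.31 log units; beyond the scatter), that is, weaker inhibition. Compound 3 `Cc1cc(=O)n(-c2ccc(F)c(F)c2)nc1C(=O)Nc1ccc(Oc2ncnc3sccc23)c(F)c1` carries instead (3,4-difluorophenyl in place of 4-methylphenyl on an aromatic nitrogen). For the measured compounds named here, this brings the group back toward the fluorine-bearing phenyl of compound 1, and the one step that bears on it, from compound 1 to compound 2, suggests that compound 3 should return to a lower number than compound 2. The expected step is therefore an at least 2.0-fold lower number from compound 2 to compound 3 (0.30 log units; that floor lies within the scatter). Compound 3 is accordingly estimated at 20000 nM, within a range from 8000 nM to 45000 nM.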

Compound 3, half-maximal inhibitory concentration: 15700 nM
The estimate for compound 3 lay 1.3-fold (0.11 log units) above the measured number, and the stated range covers the measured number.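

In this assay, putting 3,4-difluorophenyl in place of 4-methylphenyl on the aromatic nitrogen gives an at least 2.5-fold lower number from compound 2 to compound 3 (0.40 log units; beyond the scatter) and so both fluorine-bearing phenyl compounds now read lower than the methyl-bearing one. Adding a fluoro in place of a hydrogen on the aromatic carbon of the phenyl ring gives a 1.2-fold lower number from compound 1 to compound 3 (0.09 log units; within the scatter) and so compound 1 and compound 3 cannot be told apart on this read-out. The comparison with compound 2 sets only a floor, since compound 2 stands at a limit of the assay: the limit of > 40000 nM in this assay, at which 1 of the 3 values shown sits.

On these data alone, how an unsubstituted phenyl, a 4-methoxyphenyl or a pyridyl group would read on this nitrogen stays open. So does whether any group here could bring the number well below those of compound 1 and compound 3, since all three compounds shown carry a substituted phenyl.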